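From chloro to hydrogen: the step to compound 3

A few compounds are considered here, and "the series" means these few. Any claim that something is new, unique, unknown or untested is made for them only; others in the source may bear on it.

Compound 1 `COc1cc(OC)c(OC)cc1/C=C/C(=O)c1ccc(Cl)cc1` value 2.01 ug/mL
Compound 2 `COc1cc(OC)c(OC)cc1/C=C/C(=O)c1cc(Cc2ccccc2)cc(Cc2ccccc2)c1` value 2.09 ug/mL

In a functional assay, read by Griess assay, with a stated time of 2.5 h (on this read-out higher numbers stand for weaker inhibition and lower numbers for stronger inhibition), compound 1 gives 2.01 ug/mL and compound 2 gives 2.09 ug/mL on the same read-out, so the two lie within the usual scatter of each other and neither can be placed ahead. Within the data shown here, no measured pair in this small set differs in a single place, so the data do not yet show what one such change does here.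

Compound 3 (`COc1cc(OC)c(OC)cc1/C=C/C(=O)c1ccccc1`) is the next to be tested. It differs from compound 1 in one place, with hydrogen in place of chloro on an aromatic carbon, and the rest of the structure stays the same.

Among the measured compounds shown here, with no measured step to lean on, the expectation starts from compound 1 at 2.01 ug/mL and allows for a wide margin. The expected change a 1.2-fold higher number from compound 1 to compound 3 (0.09 log units; within the scatter) stays within the scatter, with no firm direction. For compound 3 the estimated value is 2.5 ug/mL with an expected range from 1 ug/mL to 6 ug/mL in this assay when it is measured.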

Compound 3, half-maximal inhibitory concentration: 2.01 ug/mL
Compound 3: middle estimate off by 1.2-fold (0.09 log units), on the high side, within the range that was stated.
By their numbers in this assay, from the lowest: compounds 1, 3 and 2 (each within the scatter of the next).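

In this assay, among these compounds, putting hydrogen in place of chloro on the aromatic carbon gives no change at the digits printed from compound 1 to compound 3 (within the scatter), and this is the only single-place step that can be read in this set. It shows that at this position, para to a large group, the chlorine atom can go without any measurable shift on this read-out, so that phenyl and 4-chlorophenyl cannot be told apart here. Nothing at hand explains this outcome.

A single pairing of chloro with hydrogen leaves open whether the same carbon would tolerate quite different groups, such as an amine, a carboxylic acid or a longer chain, or whether one of these would move the number beyond the scatter. As far as these compounds go, it also remains open whether the flat result at this position carries over to the substitution pattern of compound 2, which differs from compound 1 and compound 3 in more than one place and so cannot be set against either of them as a single step.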